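The source may hold more compounds than are shown below. What is called first, only, known or untested is meant among the compounds shown, and "the series" means these compounds.

Of the compounds shown here, three sharing one core have been measured in an assay on cells for inhibition of Palmitoleoyl-protein carboxylesterase NOTUM variant C330S (Homo sapiens), read by fluorescence, with a stated time of 40 min; on this read-out lower numbers stand for stronger inhibition and higher numbers for weaker inhibition. Compound 1 `Cc1cc(C(=O)O)c(C)n1-c1ccccc1F` gives 3300 nM in this assay. Compound 2 `Cc1cc(C(=O)O)c(C)n1-c1ccc(F)cc1` carries its fluorine elsewhere on the ring; in this assay compound 2 gives 1900 nM. How compound 1 and compound 2 differ is not broken down here. Compound 3 `Cc1ccccc1-n1c(C)cc(C(=O)O)c1C` gives 2200 nM in this assay. The values of compound 1, compound 2 and compound 3 all lie within the scatter of one another.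

Compound 3 arises from compound 1 by methyl in place of fluoro on an aromatic carbon, and that change produced a 1.5-fold lower number from compound 1 to compound 3 (0.18 log units; within the scatter). Compound 4 `Cc1ccc(-n2c(C)cc(C(=O)O)c2C)cc1`, not yet measured, arises from compound 2 by methyl in place of fluoro on an aromatic carbon. This is the same kind of change, though its place differs: in compound 3 the methyl sits ortho to a large group, in compound 4 para to a large group. Because the earlier step of a 1.5-fold lower number from compound 1 to compound 3 (0.18 log units; within the scatter) stayed within the scatter, the step from compound 2 to compound 4 in this assay is expected to be small as well, about a 1.4-fold lower number from compound 2 to compound 4 (0.13 log units; within the scatter). Compound 4 is therefore estimated at 1400 nM, likely between 600 nM and 3500 nM.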

Compound 4, half-maximal inhibitory concentration: 2000 nM
Estimate against measurement, compound 4: 1.4-fold (0.15 log units) below, and the stated range covers the measured number.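

In this assay, methyl in place of fluoro para to a large group gave a 1.1-fold higher number from compound 2 to compound 4 (0.02 log units; within the scatter), so this step, like the earlier one, is small. Set side by side, the two steps do not differ beyond what repeated measurement would allow: the same change on two cores in this assay, a 1.5-fold lower number (0.18 log units; within the scatter) from compound 1 to compound 3 and a 1.1-fold higher number (0.02 log units; within the scatter) from compound 2 to compound 4, 1.6-fold (0.20 log units) apart, within the scatter of two such steps. This shows that, across these two pairs, the change left the number within the scatter on both cores, but two such small steps cannot give the change a direction, and they show neither a real effect of the swap nor how it would behave on any other core.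

The compounds shown carry only fluoro or methyl on the aromatic ring, so it remains open whether a methoxy, an amine or a nitrile there would move the number in this assay beyond the scatter. The carboxylic acid is common to all four compounds, which also leaves open what an amide or a tetrazole in its place would do.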